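Anilinopyrimidine carbonitrile series: methylphenyl replacing trifluoromethylphenyl

This account rests on a few compounds, and the source may have more. Where it says the series, first, only, none or still open, it means among the compounds named here.

Working notes on three measured compounds and one awaiting measurement. In a functional assay on MGC-803 cells (Homo sapiens) for inhibition, read by MTT assay, with a stated time of 72 h (on this read-out higher numbers stand for weaker inhibition and lower numbers for stronger inhibition), compound 1 `C#CCSc1nc(Nc2ccc(Cl)cc2)c(C#N)c(-c2ccccc2)n1` gives only a limit, > 128000 nM. Compound 3 `Cc1ccccc1Nc1nc(SCc2cn(Cc3ccc(Cl)cc3)nn2)nc(-c2ccccc2)c1C#N` likewise gives only a limit in this assay, > 64000 nM. Going by the values given here, compound 2 `N#Cc1c(Nc2cccc(C(F)(F)F)c2)nc(SCc2cn(Cc3ccccc3Cl)nn2)nc1-c1ccccc1` is the one member of the set with a numeric value in this assay, 22800 nM, and so it is the only fixed point from which a step can be judged. The other two values, those of compound 1 and compound 3, are limits, as shown by the limit of > 128000 nM in this assay, at which 1 of the 3 values shown sits, and (the limit of > 64000 nM in this assay, at which 1 of the 3 values shown sits).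

Compound 4 `Cc1ccc(Nc2nc(SCc3cn(Cc4ccccc4Cl)nn3)nc(-c3ccccc3)c2C#N)cc1` is derived from compound 2 by a single change: 4-methylphenyl in place of 3-(trifluoromethyl)phenyl on a nitrogen on an aromatic ring. Among the compounds with values here, no measured pair in the set differs in one place, so the size of this step has no direct precedent here. Given that compound 3 sits at a limit and only compound 2 returns a number, a weakening beyond the scatter is expected for compound 4, estimated as a 2.4-fold higher number from compound 2 to compound 4 (0.38 log units; beyond the scatter) in this assay. The expected value for compound 4 in this assay is 55000 nM, within the range 15000 nM to 150000 nM, with a fair chance that only a limit is reported.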

Compound 4, half-maximal inhibitory concentration: 7190 nM
Compound 4: the middle estimate sits 7.6-fold (0.88 log units) above what was measured; measured number outside the range, below it.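

In this assay, going by these compounds alone, this is the first step that can be read at this place, on a nitrogen on an aromatic ring: a 3.2-fold lower number from compound 2 to compound 4 (0.50 log units; beyond the scatter) on going to 4-methylphenyl. With the rest of the structure held, 3-(trifluoromethyl)phenyl is therefore not needed for a numeric value, and the smaller group with no fluorine gives the stronger inhibition of this pair. No measured property of either group is available to account for the step.

A single change replaces both the substituent and its numbered place on the phenyl ring, so the pair cannot show which of these matters. Going by these compounds, how a carboxylic acid or an amine on this phenyl ring would read out also remains open.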